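A few compounds are considered here, and "the series" means these few. Any claim that something is new, unique, unknown or untested is made for them only; others in the source may bear on it.

Compound 1 `CCc1ccc(NC2=CC(=O)c3nc4n(c3C2=O)[C@H]2OC[C@@H](O)[C@H]2OC4)cc1` and compound 2 `O=C1C=C(Nc2cccc(Cl)c2)C(=O)c2c1nc1n2[C@H]2OC[C@@H](O)[C@H]2OC1` share one core and differ only in the group on the amine nitrogen. In a functional assay on MGC-803 cells (Homo sapiens) for inhibition, read by sulforhodamine B assay (on this read-out lower numbers stand for stronger inhibition and higher numbers for weaker inhibition), compound 1 gives 1290 nM, and compound 2 gives 1770 nM. Going by the values given here, the only measured step, a 1.4-fold higher number from compound 1 to compound 2 (0.14 log units; within the scatter), changes 3-chlorophenyl for 4-ethylphenyl on that nitrogen. Among the two numbers compound 2 has the highest, with compound 1 its only neighbour, and the gap between them is within the scatter.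

Compound 3 `O=C1C=C(N2CCCCC2)C(=O)c2c1nc1n2[C@H]2OC[C@@H](O)[C@H]2OC1` is not yet measured. Its change from compound 2 is piperidin-1-yl in place of (3-chlorophenyl)amino on a double-bonded ring carbon. The amine hydrogen and the aromatic ring both go, and a saturated ring takes their place. Among the compounds with values here, no measured step tells what such a change does: the single step from compound 1 to compound 2 swaps one aromatic ring for another and stays within the scatter, so it gives no direction for removing the ring altogether. The expectation is therefore a step of unknown direction, a 1.2-fold higher number from compound 2 to compound 3 (0.09 log units; within the scatter), with a wide range. Compound 3 is estimated at 2200 nM in this assay, between 700 nM and 7000 nM.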

Compound 3, half-maximal inhibitory concentration: > 8000 nM
Compound 3: a limit, no number (the forecaster's own chance of this, stated with the estimate: 10%); middle value at least 3.6-fold (0.56 log units) from the limit.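

For compound 3 the read-out in this assay is a limit and not a number: the limit of > 8000 nM in this assay, at which 1 of the 3 values shown sits.

Placing piperidin-1-yl on this double-bonded ring carbon gives an at least 4.5-fold higher number from compound 2 to compound 3 (0.65 log units; beyond the scatter), and the same group in place of (4-ethylphenyl)amino gives an at least 6.2-fold higher number from compound 1 to compound 3 (0.79 log units; beyond the scatter). Going by these compounds alone, the earlier compounds could not show this, since their only step, a 1.4-fold higher number from compound 1 to compound 2 (0.14 log units; within the scatter), exchanged one aromatic amine for another, whereas the number now proves sensitive to the group at this position once the aromatic ring and the amine hydrogen are both gone.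

Both of those features leave in a single change, which means that the compounds shown cannot tell whether the loss of the aromatic ring, the loss of the hydrogen-bond donor or the two together go with the higher number. A cyclohexylamino group, which keeps the amine hydrogen on a saturated ring, and a methyl(phenyl)amino group, which keeps the aromatic ring without that hydrogen, would pull the two features apart.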